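Aryl Replaces Isopropyl on the Ring Nitrogen

The source may hold more compounds than are shown below. What is called first, only, known or untested is meant among the compounds shown, and "the series" means these compounds.

Measured so far, in a functional assay on A549 cells (Homo sapiens) for antiproliferative activity, read by MTT assay, with a stated time of 72 h; a lower number here means a stronger inhibitor, a higher number a weaker inhibitor:
compound 1 `COc1ccc(N2C(=O)COc3ccc(-c4cnc(OC)c(NS(=O)(=O)c5ccc(F)cc5)c4)cc32)cc1` gives 1350 nM
compound 2 `COc1ncc(-c2ccc3c(c2)N(c2ccc(F)cc2)C(=O)CO3)cc1NS(=O)(=O)c1ccc(F)cc1` gives 6500 nM
compound 3 `CC(C)N1C(=O)COc2ccc(-c3cccc(NS(=O)(=O)c4ccc(F)cc4)c3)cc21` gives 29400 nM

Compound 3 gives the highest of the three numbers; its nearest neighbour is compound 2 and its furthest is compound 1. Compound 4 `Cc1ccc(N2C(=O)COc3ccc(-c4cccc(NS(=O)(=O)c5ccc(F)cc5)c4)cc32)cc1` differs from compound 3 as follows: 4-methylphenyl in place of isopropyl on an amide-type nitrogen in a ring. Going by the values given here, the only step measured, a 4.8-fold higher number from compound 1 to compound 2 (0.68 log units; beyond the scatter), concerns a change on the aromatic ring that sits on the same amide-type nitrogen, not a change from isopropyl to an aromatic ring, so it does not bear directly on this step. Compounds 1 and 2 both carry an aromatic ring on that nitrogen and both give lower numbers than compound 3, but they also differ from compound 3 elsewhere. A modest downward step is therefore expected, a 3.3-fold lower number from compound 3 to compound 4 (0.51 log units; beyond the scatter), and compound 4 is estimated at 9000 nM, within 2500 nM to 30000 nM.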

Compound 4, half-maximal inhibitory concentration: > 40000 nM
Compound 4 ended at the assay's limit; the forecaster's own chance of this, stated with the estimate: 10%; middle value at least 4.4-fold (0.64 log units) from the limit.
By their numbers in this assay, from the lowest: compound 1; then compound 2; then compound 3. At a limit, above all of these: compound 4.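

In this assay, 4-methylphenyl in place of isopropyl on this ring nitrogen gives no lower number on the core of compound 3, the opposite of the expected gain. The step is an at least 1.3-fold higher number from compound 3 to compound 4 (0.13 log units; that floor lies within the scatter), so only its floor is known, and that floor alone does not establish a real rise. The reading for compound 4 is a limit and not a number: the limit of > 40000 nM in this assay, at which 1 of the 4 values shown sits.

Going by these compounds, how this nitrogen would read carrying a methyl group, a cyclopropyl ring or a chain ending in an amine stays open.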